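The source may hold more compounds than are shown below. What is called first, only, known or untested is meant among the compounds shown, and "the series" means these compounds.

Working notes on the series. Compound 3 `COc1cc(C2=NN(C(C)=O)C(c3ccc(F)cc3)O2)cc(OC)c1OC` stands second of the three numbers in a functional assay on BGC-823 cells (Homo sapiens) for antiproliferative activity, read by MTT assay, tested at 5 uM (on this read-out lower numbers stand for a weaker effect and higher numbers for a stronger effect at the one concentration tested), where compound 3 gives 13.3%. Compound 1 `COc1ccc(C2OC(c3cc(OC)c(OC)c(OC)c3)=NN2C(C)=O)c(OC)c1` gives -3.1% in this assay, and compound 2 `COc1cc(C2=NN(C(C)=O)C(c3ccccc3C(F)(F)F)O2)cc(OC)c1OC` gives 34.8%; both steps from compound 3 lie beyond the scatter, with a number 16.4 percentage points higher from compound 1 to compound 3 (beyond the scatter) and a number 21.5 percentage points lower from compound 2 to compound 3 (beyond the scatter). Compound 4 `COc1cc(C2=NN(C(C)=O)C(c3c(Cl)cccc3Cl)O2)cc(OC)c1OC` has not been measured yet. The change from compound 3 to compound 4 is 2,6-dichlorophenyl in place of 4-fluorophenyl on a saturated ring carbon. Every measured step in this set is an exchange of the group on that same saturated ring carbon, so all three bear on it. Replacing 2,4-dimethoxyphenyl by 2-(trifluoromethyl)phenyl gave the large rise a number 37.9 percentage points higher from compound 1 to compound 2 (beyond the scatter), replacing it by 4-fluorophenyl gave the modest rise a number 16.4 percentage points higher from compound 1 to compound 3 (beyond the scatter), and the direct step from 2-(trifluoromethyl)phenyl to 4-fluorophenyl was the modest fall a number 21.5 percentage points lower from compound 2 to compound 3 (beyond the scatter). For the measured compounds named here, compound 2, carrying 2-(trifluoromethyl)phenyl, holds the highest number, but no compound with 2,6-dichlorophenyl has been measured, so the expectation is loose. A modest rise in this assay is expected for compound 4, of about a number 16.7 percentage points higher from compound 3 to compound 4 (beyond the scatter), because compound 2 gives 34.8%. The estimate for compound 4 is 30%, with a range from 10% to 50%.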

Compound 4, a percentage reported as inhibition, at one concentration (the size of the read-out at that concentration, not a potency): 15.9%
The estimate for compound 4 lay 14.1 percentage points above the measured number, and the stated range covers the measured number.
By their numbers in this assay, from the lowest: compound 1; then compounds 3 and 4 (each within the scatter of the next); then compound 2.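

In this assay, the step of a number 2.6 percentage points higher from compound 3 to compound 4 (within the scatter) lies within the scatter, so exchanging 4-fluorophenyl for 2,6-dichlorophenyl on this saturated ring carbon gives no readable change. The step of a number 18.9 percentage points lower from compound 2 to compound 4 (beyond the scatter) sets 2,6-dichlorophenyl clearly apart from 2-(trifluoromethyl)phenyl, so among these compounds, the high number of compound 2 is not shared by every aryl group carrying halogen atoms. The step of a number 19 percentage points higher from compound 1 to compound 4 (beyond the scatter) adds a third halogen-bearing aryl group that stands clear of 2,4-dimethoxyphenyl, and none of the four compounds goes against this separation.

Still open, from the compounds shown here alone, is where an unsubstituted phenyl, a 2-chlorophenyl, or a phenyl bearing an amine or a carboxylic acid would fall relative to compound 2 and to compounds 3 and 4. With a single concentration, these numbers also leave open how the compounds would rank in potency. Nothing at hand accounts for the separation of compound 2 from compounds 3 and 4.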